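The source may hold more compounds than are shown below. What is called first, only, known or untested is meant among the compounds shown, and "the series" means these compounds.

Of the compounds shown here, two have been read so far. In a functional assay on DU-145 cells (Homo sapiens) for inhibition, read by trypan blue exclusion, with a stated time of 96 h (on this read-out higher numbers stand for weaker inhibition of growth and lower numbers for stronger inhibition of growth), compound 1 `O=C(/C(=C\c1ccc(O)cc1O)S(=O)(=O)c1ccccc1Br)c1ccc(Br)cc1` gives > 100000 nM, which is a limit and not a number. In this assay, among the compounds with values here, compound 2 `Cc1cc(C)cc(/C=C(\C(=O)c2ccc(Br)cc2)S(=O)(=O)Cc2ccc(F)cc2)c1` gives 10000 nM, the only actual number available and therefore the sole anchor for what follows.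

Compound 3 `O=C(/C(=C\c1cc([N+](=O)[O-])ccc1F)S(=O)(=O)Cc1ccc(F)cc1)c1ccc(Br)cc1` has not yet been measured. It differs from compound 2 in one place: 2-fluoro-5-nitrophenyl in place of 3,5-dimethylphenyl on a double-bonded chain carbon bound to a double-bonded chain carbon. The 2-fluoro-5-nitrophenyl group thus replaces the 3,5-dimethylphenyl group on a double-bonded chain carbon bound to a double-bonded chain carbon.

Within the data shown here, no measured one-place step is available to size this change, so the expectation stays loose. The estimate is a modest step, a 2.5-fold lower number from compound 2 to compound 3 (0.40 log units; beyond the scatter), expected to lean towards stronger inhibition of growth. For compound 3 the estimated value is 4000 nM, with an expected range of 600 nM to 30000 nM.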

Compound 3, concentration for 50% growth inhibition: > 100000 nM
Compound 3 was reported as a limit; the forecaster's own chance of this, stated with the estimate: 12%; middle value at least 25-fold (1.39 log units) away from the limit.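

In this assay, the group on a double-bonded chain carbon bound to a double-bonded chain carbon is the first place shown to matter: 2-fluoro-5-nitrophenyl in place of 3,5-dimethylphenyl gives an at least 10-fold higher number from compound 2 to compound 3 (1.00 log units; beyond the scatter), towards weaker inhibition of growth. Within this pair, measurable inhibition of growth goes with the 3,5-dimethylphenyl group. The value of compound 3 is a limit and not a number, so the step gives only a minimum size: the limit of > 100000 nM in this assay, at which 2 of the 3 values shown sit.

Fluorine and the nitro group enter together, so this step cannot assign the change to either one. Still open, from the compounds shown here alone, is how a phenyl carrying only a fluorine, only a nitro group, or an amine would read at this place, and whether any such group would come closer to compound 2.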